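Piperidinylmethyl on the Chain of a Weakly Active Core

The compounds below may be only part of what the source reports. "The series", "measured", "known", "first", "only" and "open" are said of these compounds alone.

Compound 1 `CCn1c(N)c(-c2nc3ccccc3[nH]2)c2nc(C#N)c(C#N)nc21` is the starting point. In a functional assay on A549 cells (Homo sapiens) for antiproliferative activity, read by MTT assay, with a stated time of 48 h (on this read-out lower numbers stand for stronger inhibition and higher numbers for weaker inhibition), compound 1 reaches only > 50000 nM, which is a limit of the assay and not a number. Two further compounds share its core and differ only on the chain. Compound 2 `CN1CCN(CCn2c(N)c(-c3nc4ccccc4[nH]3)c3nc(C#N)c(C#N)nc32)CC1` gives 40500 nM in this assay. Compound 3 `N#Cc1nc2c(-c3nc4ccccc4[nH]3)c(N)n(CCO)c2nc1C#N` reaches only > 50000 nM in this assay, again a limit and not a number. The step of an at least 1.2-fold lower number from compound 1 to compound 2 (0.09 log units; that floor lies within the scatter) is the only one that can be read, while a step that the two limits leave unreadable from compound 1 to compound 3 cannot be sized; the limit of > 50000 nM in this assay, at which 2 of the 3 values shown sit, frames both. Compound 4 `N#Cc1nc2c(-c3nc4ccccc4[nH]3)c(N)n(CCCN3CCCCC3)c2nc1C#N` is not yet measured; it differs from compound 1 by (piperidin-1-yl)methyl in place of hydrogen on a saturated chain carbon, two bonds along the chain from an aromatic nitrogen. Going by the values given here, of the measured steps only the one to compound 2 bears on it, where 4-methylpiperazin-1-yl entered at the same place, and that step was small. Compound 4 is therefore expected to show an at least 1.4-fold lower number from compound 1 to compound 4 (0.15 log units; that floor lies within the scatter), with nothing assured beyond the scatter. Compound 4 is expected to give about 35000 nM in this assay, within a range from 15000 nM to 60000 nM.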

Compound 4, half-maximal inhibitory concentration: 6110 nM
The estimate for compound 4 lay 5.7-fold (0.76 log units) above the measured number; measured number below the stated range.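

Going by these compounds alone, on the saturated chain carbon, two bonds along the chain from an aromatic nitrogen, (piperidin-1-yl)methyl gives the first steps in this assay that lie beyond the scatter: an at least 8.1-fold lower number from compound 1 to compound 4 (0.91 log units; beyond the scatter) and an at least 8.1-fold lower number from compound 3 to compound 4 (0.91 log units; beyond the scatter). A ring at the chain end does not settle the outcome alone, as the change to compound 4 also separates it from the other ring-bearing compound, with a 6.6-fold lower number from compound 2 to compound 4 (0.82 log units; beyond the scatter), though this step exchanges the ring and lengthens the chain together. The first two steps are floors and not sizes: the limit of > 50000 nM in this assay, at which 2 of the 4 values shown sit.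

The compounds shown leave open whether the gain follows the piperidine ring or the chain length, which a 2-(piperidin-1-yl)ethyl or a 3-(4-methylpiperazin-1-yl)propyl group would separate. Also open, from the compounds shown here alone, is how a morpholine, a primary amine or a longer chain would read at this place.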